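Carbamoyl in Place of Hydroxy on the Shared Core

The source may hold more compounds than are shown below. What is called first, only, known or untested is meant among the compounds shown, and "the series" means these compounds.

Three compounds have been measured in a functional assay on CHO cells for agonist activity at metabotropic glutamate receptor 5 (Homo sapiens), read by inositol phosphate accumulation; on this read-out lower numbers stand for stronger inhibition and higher numbers for weaker inhibition:
Compound 1, `Cc1nc(C#Cc2cccc(C(F)(F)F)c2)cs1`: 413 nM
Compound 2, `CC(=O)Nc1cccc(C#Cc2csc(C)n2)c1`: 2020 nM
Compound 3, `Cc1nc(C#Cc2cccc(O)c2)cs1`: 654 nM

All three share one core and differ only in the group on the six-membered carbon ring. Compound 3 gives the second highest of the three numbers in this assay: it stands close to compound 1, a 1.6-fold higher number from compound 1 to compound 3 (0.20 log units; within the scatter), while the gap to compound 2 is wider, a 3.1-fold lower number from compound 2 to compound 3 (0.49 log units; beyond the scatter).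

Compound 4, `Cc1nc(C#Cc2cccc(C(N)=O)c2)cs1`, has not yet been measured. It differs from compound 3 in one place: carbamoyl in place of hydroxy on an aromatic carbon

Among the compounds with values here, two measured steps bear on this change. The step of a 3.1-fold lower number from compound 2 to compound 3 (0.49 log units; beyond the scatter) shows that replacing an amide-bearing group by hydroxy lowered the number beyond the scatter; the reverse direction, hydroxy to an amide-bearing group, would then be expected to raise it. The step of a 1.6-fold higher number from compound 1 to compound 3 (0.20 log units; within the scatter) shows that hydroxy and trifluoromethyl sit within the scatter of each other. Carbamoyl, like acetamido, carries an amide, though it is smaller, so a modest rise is expected rather than a large one.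

The estimate for compound 4 in this assay is therefore 1400 nM, with a range from 500 nM to 4000 nM, which would mean a step of a 2.1-fold higher number from compound 3 to compound 4 (0.33 log units; beyond the scatter) expected from compound 3.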

Compound 4, half-maximal inhibitory concentration: 1000 nM
The estimate for compound 4 lay 1.4-fold (0.15 log units) above the measured number; the range from low to high includes it.
By their numbers in this assay, from the lowest: compounds 1, 3 and 4 (each within the scatter of the next, the first and the last beyond it); then compound 2.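

In this assay, the change from hydroxy to carbamoyl gives a step that cannot be told apart from the usual scatter (a 1.5-fold higher number from compound 3 to compound 4 (0.18 log units; within the scatter)), so these two groups cannot be ranked at this position on the shared core. Carrying an amide does not by itself settle the number here, since the two amide-bearing groups, acetamido and carbamoyl, stand apart by more than the scatter (a 2.0-fold lower number from compound 2 to compound 4 (0.31 log units; beyond the scatter)). Carbamoyl also separates from trifluoromethyl (a 2.4-fold higher number from compound 1 to compound 4 (0.38 log units; beyond the scatter)), which hydroxy did not do, so hydroxy now lies within the scatter of both groups while those two lie beyond it from each other, and the three read as a shallow slope rather than as clear classes.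

The compounds shown leave open how far the number would move with other groups at this position, such as an amine, a carboxylic acid, a nitrile or a longer chain ending in an amide. Nothing among the available data accounts for why acetamido and carbamoyl differ in this way.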